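Benzyl-substituted nucleosides tested against melanoma cells

This account rests on a few compounds, and the source may have more. Where it says the series, first, only, none or still open, it means among the compounds named here.

Measured compounds:
- compound 1, `COc1cccc(CNc2ncnc3c2ncn3[C@@H]2O[C@H](CO)[C@@H](O)[C@H]2O)c1`: "not determined" (no result reported)
- compound 2, `OC[C@H]1O[C@@H](n2cnc3c(NCc4ccc(F)cc4F)ncnc32)[C@H](O)[C@@H]1O`: > 166000 nM

Both compounds share one nucleoside core and differ only in the substituted benzyl group on the amine. In a functional assay on G-361 cells (Homo sapiens) for antiproliferative activity, with a stated time of 72 h (on this read-out higher numbers stand for weaker inhibition and lower numbers for stronger inhibition), compound 1 has no single number, so it stands nowhere on a scale yet. For compound 2 the result is a limit of the assay, > 166000 nM, not a number, as the limit of > 166000 nM in this assay, at which 1 of the 2 values shown sits, records. Compound 3, `Cc1ccc(O)c(CNc2ncnc3c2ncn3[C@@H]2O[C@H](CO)[C@@H](O)[C@H]2O)c1`, is the next compound to be tested. It differs from compound 1 as follows: 2-hydroxy-5-methylphenyl in place of 3-methoxyphenyl on a saturated chain carbon bound to a nitrogen on an aromatic ring. Among the compounds with values here, because compound 1 has no result and compound 2 only (the limit of > 166000 nM in this assay, at which 1 of the 2 values shown sits), no direction for the step from compound 1 to compound 3 can be read from the data, and no size beyond the scatter is expected. Compound 3 is expected to give about 100000 nM, with a range from 20000 nM to 500000 nM, and a fair chance of only a limit.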

Compound 3, half-maximal inhibitory concentration: > 166000 nM
Compound 3 ended at the assay's limit (the forecaster's own chance of this, stated with the estimate: 55%); middle value at least 1.6-fold (0.22 log units) away from the limit.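

Compound 2 and compound 3 both end at a limit rather than a number, so no step between them can be read from this assay: the limit of > 166000 nM in this assay, at which 2 of the 3 values shown sit.

The compounds shown leave open whether any substituted benzyl group on the shared core gives measurable inhibition of these cells.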